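Sulfonyl substituent variation, compound 3 to compound 4

This account rests on a few compounds, and the source may have more. Where it says the series, first, only, none or still open, it means among the compounds named here.

In an assay on isolated protein for inhibition of 5-hydroxytryptamine receptor 4 (Homo sapiens) (a lower number here means a stronger inhibitor, a higher number a weaker inhibitor), compound 1 `CC1(C)CCN(S(=O)(=O)CCCN2CCC(CNC(=O)c3cccc4c3OCCO4)CC2)CC1` gives 0.126 nM, compound 2 `O=C(NCC1CCN(CCCS(=O)(=O)N2CCOCC2)CC1)c1cccc2c1OCCO2` gives 0.398 nM and compound 3 `O=C(NCC1CCN(CCCS(=O)(=O)N2CCN(c3ccccn3)CC2)CC1)c1cccc2c1OCCO2` gives 0.251 nM. Compound 3 thus holds the second highest of the three numbers, with a 1.6-fold lower number from compound 2 to compound 3 (0.20 log units; within the scatter) and a 2.0-fold higher number from compound 1 to compound 3 (0.30 log units; within the scatter). Compound 4 `O=C(NCC1CCN(CCCS(=O)(=O)N2CCN(C3CCCC3)CC2)CC1)c1cccc2c1OCCO2` differs from compound 3 by cyclopentyl in place of pyridin-2-yl on an amine nitrogen in a ring. Among the compounds with values here, no measured step alters this outer group alone; the steps that do touch the group on the sulfonyl sulfur, a 3.2-fold higher number from compound 1 to compound 2 (0.50 log units; beyond the scatter) and a 2.0-fold higher number from compound 1 to compound 3 (0.30 log units; within the scatter), were modest or within the scatter, so the region tolerates change. A step within the scatter is therefore expected, a 1.0-fold lower number from compound 3 to compound 4 (0.00 log units; within the scatter). Compound 4 is estimated at 0.25 nM, in the range 0.1 nM to 0.63 nM.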

Compound 4, inhibition constant: 0.0159 nM
Compound 4: middle estimate off by 16-fold (1.20 log units), on the high side; measured number outside the range, below it.
By their numbers in this assay, from the lowest: compound 4; then compounds 1, 3 and 2 (each within the scatter of the next, the first and the last beyond it).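

Within the data shown here, the group on the amine nitrogen in a ring is less tolerant than the earlier compounds suggested: cyclopentyl in place of pyridin-2-yl gives a 16-fold lower number from compound 3 to compound 4 (1.20 log units; beyond the scatter). The whole group on the sulfonyl sulfur also carries more weight, with 4-cyclopentylpiperazin-1-yl giving a 25-fold lower number from compound 2 to compound 4 (1.40 log units; beyond the scatter) and a 7.9-fold lower number from compound 1 to compound 4 (0.90 log units; beyond the scatter). Nothing at hand accounts for these steps.

Whether the drop belongs to cyclopentyl alone stays open, as it is the only carbon-only ring shown at this nitrogen. Phenyl, cyclohexyl or isopropyl there would separate ring size from aromatic versus non-aromatic ring.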